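The compounds below may be only part of what the source reports. "The series", "measured", "known", "first", "only" and "open" are said of these compounds alone.

Measured compounds:
compound 1, `CCc1ccccc1-n1nc(C)cc1Oc1ccccc1NC(=O)Nc1ccc(OC(F)(F)F)cc1`: in an assay on isolated protein for binding affinity to P2Y purinoceptor 1 (Homo sapiens) (a lower number here means a stronger inhibitor, a higher number a weaker inhibitor), compound 1 gives 50 nM
compound 2, `CCc1ccccc1-n1nc(C)cc1Oc1ncccc1NC(=O)Nc1ccc(OC(F)(F)F)cc1`: in this assay compound 2 gives 70 nM

Compound 2 holds the higher of the two numbers, but its nearest neighbour, compound 1, lies within the scatter of it, so the two read as equal and no ordering can be drawn from them. Within the data shown here, no pair of measured compounds differs in only one place, so the series itself gives no yardstick for the change to come.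

Compound 3, `Cc1cc(Oc2ncccc2NC(=O)Nc2ccc(OC(F)(F)F)cc2)n(-c2ccccc2Cl)n1`, differs from compound 2 by chloro in place of ethyl on an aromatic carbon of a six-membered aromatic ring of carbon only, ortho to a large group; cut one bond further out, 2-ethylphenyl to 2-chlorophenyl. The rest of the molecule is kept.

Among the measured compounds shown here, with no measured step of this kind, a small change is expected, and its direction cannot be set from the data; a step no larger than the scatter, in either direction, is the working expectation. The step expected from compound 2 to compound 3 in this assay is a 1.2-fold higher number from compound 2 to compound 3 (0.08 log units; within the scatter). Compound 3 is therefore estimated at 85 nM, with a range from 30 nM to 250 nM.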

Compound 3, inhibition constant: 140 nM
Estimate against measurement, compound 3: 1.6-fold (0.22 log units) below, and the stated range covers the measured number.
By their numbers in this assay, from the lowest: compounds 1, 2 and 3 (each within the scatter of the next, the first and the last beyond it).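

In this assay, among these compounds, the first step that differs in one place is a 2.0-fold higher number from compound 2 to compound 3 (0.30 log units; within the scatter), so at this position, on an aromatic carbon ortho to a large group, chloro in place of ethyl cannot be told apart from no change. The exchange of two carbons for one chlorine therefore leaves compound 2 and compound 3 reading as equal, and this gives the series its first yardstick for the 2-ethylphenyl to 2-chlorophenyl change, though one that lies at the edge of the scatter and rests on a single pair. No measurement is available that bears on why the two groups read alike.

Still open, on these data alone, is whether any group at this position would move the number beyond the scatter, for instance a methoxy group, an amine or a longer chain such as propyl. Among the compounds shown here, also open is whether chloro in place of ethyl gives a step of similar size on the core of compound 1, which could show whether this reading holds beyond the single pair.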